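Cytotoxicity notes: isopropylpiperidine to spiro-azetidine swap

This account rests on a few compounds, and the source may have more. Where it says the series, first, only, none or still open, it means among the compounds named here.

Measured so far in an ADME assay on Vero cells (Chlorocebus sabaeus) for cytotoxicity, with a stated time of 7 days; a higher number here means that more compound is tolerated, a lower number that less compound is tolerated:
Compound 1 `COc1ccc2[nH]c(C(=O)N3CC(=O)N(Cc4ccccc4)[C@@H](COc4ccccc4)C3)cc2c1` gives > 10000 nM; this is a limit of the assay, not a number.
Compound 2 `COc1ccc2[nH]c(C(=O)N3CC(=O)N(Cc4ccccc4)[C@@H](CN4CCC(C)CC4)C3)cc2c1` gives > 30000 nM; this too is a limit.
Compound 3 `COc1ccc2[nH]c(C(=O)N3CC(=O)N(Cc4ccccc4)[C@@H](CN4CCC(C(C)C)CC4)C3)cc2c1` gives 3800 nM.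

Among the compounds with values here, compound 3 therefore holds the only actual number in this assay; the other two values sit at limits, the limit of > 10000 nM in this assay, at which 1 of the 3 values shown sits, and (the limit of > 30000 nM in this assay, at which 1 of the 3 values shown sits), and read as the better-tolerated pair. The next compound, compound 4 `COc1ccc2[nH]c(C(=O)N3CC(=O)N(Cc4ccccc4)[C@@H](CN4CC5(CCC5)C4)C3)cc2c1`, changes the same position: a group of 7 heavy atoms (6 carbon, 1 nitrogen; one four-membered non-aromatic ring of carbon only, one four-membered non-aromatic ring with 1 hetero atom) in place of a group of 9 heavy atoms (8 carbon, 1 nitrogen; one six-membered non-aromatic ring with 1 hetero atom), on a saturated chain carbon bound to a saturated ring carbon.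

Within the data shown here, two measured steps bear on this position. an at least 7.8-fold lower number from compound 2 to compound 3 (0.89 log units; beyond the scatter), so the larger substituent on the piperidine went with the lower number. an at least 2.6-fold lower number from compound 1 to compound 3 (0.42 log units; beyond the scatter) points the same way. a step that the two limits leave unreadable from compound 1 to compound 2, so no size can be read there.

Among the measured compounds shown here, compound 4 carries the smaller of the two groups in the change, and the only readable steps at this position pair the larger group with the lower number. The expectation for compound 4 is thus a higher number than compound 3, a 5.3-fold higher number from compound 3 to compound 4 (0.72 log units; beyond the scatter), with a fair chance that only a limit is recorded. The estimate for compound 4 in this assay is 20000 nM, within 6000 nM to 60000 nM.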

Compound 4, half-maximal cytotoxic concentration: 52700 nM
Estimate against measurement, compound 4: 2.6-fold (0.42 log units) below; the range from low to high includes it.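

In this assay, the group of 7 heavy atoms with its two four-membered rings, in place of 4-isopropylpiperidin-1-yl, gives a 14-fold higher number from compound 3 to compound 4 (1.14 log units; beyond the scatter), so the tolerance lost with the isopropyl group is regained without a piperidine ring at this position. Compound 4 also gives the first actual number on the well-tolerated side of the series, whereas compound 1 and compound 2 stand only at limits, and the link between the larger group and the lower number now rests on one measured step with no limit in it; none of the compounds shown goes against that link. The steps to compound 4 from compound 1 and from compound 2 cannot be read; both earlier values are limits.

Nothing measured here says what lies behind the step from the piperidine to the group with two four-membered rings. Open too, from the compounds shown here alone, is whether the number tracks group size or ring type, which a 4-ethylpiperidin-1-yl group, a morpholine or a carboxylic acid on the four-membered ring of carbon would begin to separate.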